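Dichloro Step in a Cytotoxicity Series

A few compounds are considered here, and "the series" means these few. Any claim that something is new, unique, unknown or untested is made for them only; others in the source may bear on it.

Compound 1 `c1ccc([C@@H]2C[C@@H]3Cc4ccc5ccccc5c4N2O3)cc1`: > 350000 nM
Compound 2 `Clc1ccccc1[C@@H]1C[C@@H]2Cc3ccc4ccccc4c3N1O2`: > 300000 nM

In an ADME assay on THP-1 cells (Homo sapiens) for cytotoxicity, read by MTT assay, with a stated time of 72 h (a higher number here means that more compound is tolerated, a lower number that less compound is tolerated), compound 1 reaches only a limit, > 350000 nM. Compound 2 likewise gives only a limit, > 300000 nM. The step that the two limits leave unreadable from compound 1 to compound 2 is therefore unreadable, since compound 2 sits at the limit of > 300000 nM in this assay, at which 1 of the 2 values shown sits, and compound 1 at the limit of > 350000 nM in this assay, at which 1 of the 2 values shown sits. Compound 3 `Clc1ccc([C@@H]2C[C@@H]3Cc4ccc5ccccc5c4N2O3)c(Cl)c1` differs from compound 2 by chloro in place of hydrogen on an aromatic carbon. Within the data shown here, the only measured step bears on it without giving a size, and no measured step points in either direction. A step of a number no higher from compound 2 to compound 3 (the limit leaves the size open) of no size beyond the scatter is expected, and compound 3 is estimated at 300000 nM (range 100000 nM to 600000 nM) in this assay, most likely again reported as a limit.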

Compound 3, half-maximal cytotoxic concentration: > 250000 nM
Compound 3: only a limit was reported (the forecaster's own chance of this, stated with the estimate: 70%); the middle value lies beyond the limit too.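

In this assay compound 3 gives only a limit, > 250000 nM. Among these compounds, no step among compound 1, compound 2 and compound 3 can be read. The compounds shown leave open whether either chloro group changes how much compound is tolerated.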